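From bromo to nitro on a shared core

The compounds below may be only part of what the source reports. "The series", "measured", "known", "first", "only" and "open" are said of these compounds alone.

compound 1 `CCOc1ccc(NC(=O)c2cc3cc(Br)ccc3oc2=O)cc1` gives 16800 nM
compound 2 `O=C(N/N=C/c1cccnc1)c1cc2ccc(O)cc2oc1=O` gives 2530 nM
compound 3 `CCOc1ccc2nc(Cl)c(/C=N/NC(=O)c3cc4ccccc4oc3=O)cc2c1` gives 29900 nM

In a functional assay on PANC-1 cells (Homo sapiens) for antiproliferative activity, read by fluorescence and resazurin assay, with a stated time of 48 h (on this read-out lower numbers stand for stronger inhibition and higher numbers for weaker inhibition), compound 1 gives 16800 nM and lies within the scatter of compound 3 at 29900 nM while compound 2 at 2530 nM stands clearly lower, which means stronger inhibition. Compound 4 `CCOc1ccc(NC(=O)c2cc3cc([N+](=O)[O-])ccc3oc2=O)cc1` keeps the core of compound 1 and has nitro in place of bromo on an aromatic carbon, a change counted as nitro in place of bromo on an aromatic carbon here. Among the compounds with values here, no measured pair shows this kind of swap, so the data give no guide to its direction, and no shift beyond the scatter is expected in this assay here. The estimated step is a 1.2-fold lower number from compound 1 to compound 4 (0.08 log units; within the scatter) and so stays within the scatter. For compound 4 the estimated value is 14000 nM with an expected range from 5000 nM to 40000 nM as its limits.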

Compound 4, half-maximal inhibitory concentration: 12100 nM
The estimate for compound 4 lay 1.2-fold (0.06 log units) above the measured number, within the range that was stated.
By their numbers in this assay, from the lowest: compound 2; then compounds 4, 1 and 3 (each within the scatter of the next, the first and the last beyond it).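

Within the data shown here, compound 1 and compound 4 form the first pair here that differs in only one place, so this position can now be read directly. In this assay, nitro in place of bromo gives a 1.4-fold lower number from compound 1 to compound 4 (0.14 log units; within the scatter), so this position accepts a group with more heavy atoms and with hydrogen-bond acceptors without a change beyond the scatter. Nothing available explains why the number stays within the scatter. Still open, on these data alone, is whether an amine or a carboxylic acid on this aromatic carbon would move the number beyond the scatter.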